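Cyano in Place of Fluoro: One Step Ahead

The compounds below may be only part of what the source reports. "The series", "measured", "known", "first", "only" and "open" are said of these compounds alone.

Measured so far in an ADME assay on a cell-free system (plasma, Homo sapiens); on this read-out higher numbers stand for a larger free fraction and lower numbers for a smaller free fraction:
Compound 1 `CCNC(=O)Nc1nc2cc(-c3cccnc3)c(=O)n(CC3CC3)c2s1`: 0.05
Compound 2 `CCNC(=O)Nc1nc2cc(-c3cncc(F)c3)c(=O)n(C(C)C)c2s1`: 0.1

Within the data shown here, only two compounds have been measured so far. Compound 2 gives 0.1 and compound 1 gives 0.05, and this gap lies within the usual scatter of repeated measurements. Neither compound therefore stands clearly apart from the other. The two differ in more than one place, so the pair does not show what any single change does.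

The next compound, compound 3 `CCNC(=O)Nc1nc2cc(-c3cncc(C#N)c3)c(=O)n(C(C)C)c2s1`, keeps the rest of compound 2 and carries cyano in place of fluoro on an aromatic carbon. The change turns 5-fluoropyridin-3-yl into 5-cyanopyridin-3-yl.

Among the measured compounds shown here, no measured pair shows this swap, or any other single change, in this assay. The step of no change at the digits printed from compound 2 to compound 3 (within the scatter) is therefore expected to stay within the scatter, with neither direction favoured. The expectation rests on the closest measured relative, compound 2 at 0.1. For compound 3 the expected value is 0.1, with an estimated range from 0.05 to 0.2.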

Compound 3, unbound fraction in the plasma assay: 0.1
Compound 3: the middle estimate sits on the measured number at the digits printed, within the range that was stated.
By their numbers in the plasma assay, from the lowest: compounds 1, 2 and 3 (each within the scatter of the next).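

Among these compounds, this is the first single change that can be read in the plasma assay: on this aromatic carbon, two atoms from the ring nitrogen, cyano in place of fluoro gives no change at the digits printed from compound 2 to compound 3 (within the scatter), so the free fraction does not separate these two groups at this position. The same swap does show in a physicochemical assay for solubility, in phosphate buffer, at pH 7.4 (on this read-out higher numbers stand for higher solubility and lower numbers for lower solubility), where solubility falls well past the scatter: the measured solubility of compound 2, 73000 nM, and of compound 3, < 5000 nM, an at least 14-fold lower number (1.16 log units; beyond the scatter). In the physicochemical assay compound 2 gives 73000 nM. In the physicochemical assay compound 3 gives < 5000 nM, which is a limit of the assay, not a number: the limit of < 5000 nM in the physicochemical assay, at which 1 of the 2 values shown sits.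

As far as these compounds go, whether another group on this carbon, such as an amine, a carboxylic acid or a methoxy group, would leave the free fraction in the plasma assay where it stands, and what it would do to the solubility in the physicochemical assay, stays open. Also open is whether cyano in place of fluoro would give the same two results with the rest of the molecule changed, since the compounds shown hold only this one pair that differs in a single place.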